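Iodine in Place of Thiophene on a Shared Core

The source may hold more compounds than are shown below. What is called first, only, known or untested is meant among the compounds shown, and "the series" means these compounds.

The compounds were compared in a functional assay on HCT-116 cells (Homo sapiens), read by MTT assay, with a stated time of 72 h; on this read-out lower numbers stand for stronger inhibition and higher numbers for weaker inhibition. Compound 1 `COc1ncnc2c1c(-c1ccsc1)cn2[C@@H]1O[C@H](CO)[C@@H](O)[C@H]1O` gives 120 nM in this assay. Compound 2 `COc1nc(N)nc2c1c(-c1ccccc1)cn2[C@@H]1O[C@H](CO)[C@@H](O)[C@H]1O` reports only a limit of this assay, > 20000 nM, and not a number. Compound 3 `Cc1nc(N)c2c(-c3cccs3)cn([C@@H]3O[C@H](CO)[C@@H](O)[C@H]3O)c2n1` likewise reports only a limit, > 20000 nM. On the numbers shown, compound 3 therefore stands at the limit of > 20000 nM in this assay, at which 2 of the 3 values shown sit, with no measured value of its own. The change to compound 4 `Cc1nc(N)c2c(I)cn([C@@H]3O[C@H](CO)[C@@H](O)[C@H]3O)c2n1` consists of iodo in place of thiophen-2-yl on an aromatic carbon. For the measured compounds named here, no step between measured compounds is available to anchor this change, and compound 3 itself provides only a limit. Compound 4 is nevertheless expected to move toward stronger inhibition, beyond the scatter, by an at least 4.0-fold lower number from compound 3 to compound 4 (0.60 log units; beyond the scatter). Compound 4 is estimated at 5000 nM, with a range from 500 nM to 20000 nM.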

Compound 4, half-maximal inhibitory concentration: > 20000 nM
Compound 4: only a limit was reported (the forecaster's own chance of this, stated with the estimate: 40%); middle value at least 4.0-fold (0.60 log units) away from the limit.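

For the compounds shown here, compound 4 reports only a limit in this assay, > 20000 nM, so no step from compound 3 to compound 4 can be read. The compounds shown leave open how iodo and thiophen-2-yl compare on the shared core, since the values stop at one limit: the limit of > 20000 nM in this assay, at which 3 of the 4 values shown sit.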